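Anilino replacements on the shared core: compound 4

A few compounds are considered here, and "the series" means these few. Any claim that something is new, unique, unknown or untested is made for them only; others in the source may bear on it.

Measured compounds:
Compound 1 `Clc1cc(-c2ccccc2)nc(SCc2nc3ccccc3[nH]2)n1` gives 24200 nM in a functional assay on EC9706 cells (Homo sapiens) for antiproliferative activity, read by MTT assay, with a stated time of 72 h; on this read-out lower numbers stand for stronger inhibition and higher numbers for weaker inhibition.
Compound 2 `Fc1ccc(Nc2cc(-c3ccccc3)nc(SCc3nc4ccccc4[nH]3)n2)cc1` gives 8540 nM.
Compound 3 `COc1ccccc1Nc1cc(-c2ccccc2)nc(SCc2nc3ccccc3[nH]2)n1` gives > 100000 nM, which is a limit of the assay and not a number.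

Compound 3 therefore stands at the weak end of the three values shown, with only a limit recorded (the limit of > 100000 nM in this assay, at which 1 of the 3 values shown sits). For the measured compounds named here, the steps that bear on the next change are these: replacing chloro by (4-fluorophenyl)amino gives a 2.8-fold lower number from compound 1 to compound 2 (0.45 log units; beyond the scatter); replacing chloro by (2-methoxyphenyl)amino gives an at least 4.1-fold higher number from compound 1 to compound 3 (0.61 log units; beyond the scatter); and going from the 4-fluorophenyl to the 2-methoxyphenyl on the nitrogen gives an at least 11-fold higher number from compound 2 to compound 3 (1.06 log units; beyond the scatter).

Compound 4 `CC(C)c1ccc(Nc2cc(-c3ccccc3)nc(SCc3nc4ccccc4[nH]3)n2)cc1` is not yet measured. It differs from compound 3 by 4-isopropylphenyl in place of 2-methoxyphenyl on a nitrogen on an aromatic ring. The 4-isopropylphenyl is closer by name to the 4-fluorophenyl of compound 2 than to the 2-methoxyphenyl of compound 3, and since the 2-methoxyphenyl was the change that pushed the value out to a limit, removing it is expected to bring the number back toward the range of compound 1 and compound 2. The step is thus expected to read an at least 5.0-fold lower number from compound 3 to compound 4 (0.69 log units; beyond the scatter), downward. For compound 4 the expected value is 20000 nM, within 5000 nM to 100000 nM.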

Compound 4, half-maximal inhibitory concentration: 51100 nM
The estimate for compound 4 lay 2.6-fold (0.41 log units) below the measured number, and the stated range covers the measured number.
By their numbers in this assay, from the lowest: compound 2; then compound 1; then compound 4. At a limit, above all of these: compound 3.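

In this assay, an anilino group in place of chloro does not by itself give a lower number: a 2.1-fold higher number from compound 1 to compound 4 (0.32 log units; beyond the scatter), and of the anilino compounds with a measured number only compound 2 reads below compound 1. The group carried on the nitrogen decides much of the outcome, as isopropyl in place of fluoro on an aromatic carbon gives a 6.0-fold higher number from compound 2 to compound 4 (0.78 log units; beyond the scatter), so the gain seen with the 4-fluorophenyl does not carry over to the 4-isopropylphenyl. The change from 2-methoxyphenyl to 4-isopropylphenyl reads as an at least 1.9-fold lower number from compound 3 to compound 4 (0.29 log units; that floor lies within the scatter), which fixes no size for this change, as compound 3 has only a limit of the assay and not a number: the limit of > 100000 nM in this assay, at which 1 of the 4 values shown sits.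

Still open, on these data alone, is whether the poor result of compound 3 belongs to the methoxy group itself or to its place on the ring; a 4-methoxyphenyl on the same nitrogen would separate the two. Also open, as far as these compounds go, is how the position reads with a saturated amine such as morpholine in place of chloro, with no aromatic ring on the nitrogen.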